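Swapping the group on sulfur: compound 2 to compound 3

The source may hold more compounds than are shown below. What is called first, only, known or untested is meant among the compounds shown, and "the series" means these compounds.

Among the measured compounds shown here, in a functional assay on MT4 cells (Homo sapiens) for cytotoxicity, read by MTT assay (a higher number here means that more compound is tolerated, a lower number that less compound is tolerated), compound 2 `Cc1c(O)nc(Sc2ccc(C#N)cc2)nc1Cc1c(Cl)cccc1Cl` gives 27600 nM, the only actual number so far. Compound 1 `Cc1c(O)nc(Sc2ccc(F)cc2F)nc1Cc1c(Cl)cccc1Cl` is recorded only as a limit, > 60500 nM. Compound 3 `COc1ccc(Sc2nc(O)c(C)c(Cc3c(Cl)cccc3Cl)n2)cn1` differs from compound 2 on a sulfur: 6-methoxypyridin-3-yl in place of 4-cyanophenyl on a sulfur. For the measured compounds named here, the one measured step at this place is an at least 2.1-fold lower number from compound 1 to compound 2 (0.34 log units; beyond the scatter), and it brought 4-cyanophenyl in. On these data alone, with that group leaving, a modest move to a higher number is expected, though 6-methoxypyridin-3-yl itself is untested. The expected change is a 1.4-fold higher number from compound 2 to compound 3 (0.16 log units; within the scatter). For compound 3 the estimate is 40000 nM, with an expected range of 15000 nM to 100000 nM.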

Compound 3, half-maximal cytotoxic concentration: > 61300 nM
Compound 3 ended at the assay's limit; the forecaster's own chance of this, stated with the estimate: 35%; middle value at least 1.5-fold (0.18 log units) from the limit.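

In this assay, among the compounds shown here, this sulfur position gives a second readable step, an at least 2.2-fold higher number from compound 2 to compound 3 (0.34 log units; beyond the scatter), and 4-cyanophenyl remains the only group here with an actual number. Compound 3 is recorded only as a limit: the limit of > 61300 nM in this assay, at which 1 of the 3 values shown sits. Compound 1 is also recorded as a limit, and the step between compound 1 and compound 3 cannot be read.

On these data alone, how far the values of compound 1 and compound 3 lie beyond their limits stays open. Also open, as far as these compounds go, is what an aminophenyl group or a plain alkyl chain on this sulfur would give in this assay.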